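Fluoro for trifluoromethyl: expected half-life shift

The source may hold more compounds than are shown below. What is called first, only, known or untested is meant among the compounds shown, and "the series" means these compounds.

Of the compounds shown here, two have been measured so far in an ADME assay for pharmacokinetics, read by LC-MS, in phosphate buffer, with a stated time of 120 min, at pH 7.4, tested at 1 uM, in the presence of a further agent that is not named here; a higher number here means that the compound lasts longer, a lower number that the compound disappears faster. Compound 1 (`C=C(C(=O)Nc1ccccc1)C(F)(F)F`) gives 0.25 h as its half-life, the lower of the two numbers. Compound 2 (`CN(C)CC/C=C/C(=O)Nc1ccccc1`) gives 7.38 h as its half-life, and this gap lies beyond the usual scatter. The two compounds differ in more than one place, so their gap does not isolate any single structural change.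

Compound 3 (`C=C(F)C(=O)Nc1ccccc1`) keeps the core of compound 1 and carries fluoro in place of trifluoromethyl on a double-bonded chain carbon bound to a carbonyl carbon. Within the data shown here, no measured pair shows this change, so the expectation below is a judgement and not a read-across. Compound 1 stands at the bottom of the measured span with 0.25 h as its half-life, and compound 2 shows that much higher numbers occur in this assay. A rise beyond the scatter is expected, and the estimated size is an 8.0-fold higher number from compound 1 to compound 3 (0.90 log units; beyond the scatter) in this series. Compound 3 is expected at 2 h with a range from 0.6 h to 7 h as its estimated half-life.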

Compound 3, half-life: > 8.53 h
Compound 3 was reported as a limit (the forecaster's own chance of this, stated with the estimate: 10%); middle value at least 4.2-fold (0.62 log units) from the limit.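

In this assay, fluoro in place of trifluoromethyl on a double-bonded chain carbon bound to a carbonyl carbon gives an at least 34-fold higher number from compound 1 to compound 3 (1.53 log units; beyond the scatter), and this is the only step shown that differs in one place. The gap between compound 1 and compound 2 could not be tied to any single change, whereas this step ties a large change in half-life to the group at this one position, with the shared core unchanged. Compound 3 stands at > 8.53 h, which is a limit of the assay and not a number: the limit of > 8.53 h in this assay, at which 1 of the 3 values shown sits.

The compounds shown leave open where a group such as methyl or chloro, on a double-bonded chain carbon bound to a carbonyl carbon, would fall in this assay, since trifluoromethyl and fluoro are the only two groups compared at this position. They also leave open how far compound 3 lies past its limit, and whether the exchange of trifluoromethyl for fluoro has a step of similar size on any core other than that of compound 1.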